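The source may hold more compounds than are shown below. What is called first, only, known or untested is meant among the compounds shown, and "the series" means these compounds.

Series notes. Compound 1 `CC(C)(Oc1ccc(Cl)cc1)C(=O)N1CCN(c2nc(N)nc3sc(-c4ccc(F)cc4)nc23)CC1` and compound 2 `Nc1nc(N2CCN(S(=O)(=O)c3ccccc3)CC2)c2nc(-c3ccc(F)cc3)sc2n1` share a core and differ in the group on the piperazine nitrogen. In a functional assay on cells (Lymphocyte, Homo sapiens) (a higher number here means a weaker inhibitor, a lower number a stronger inhibitor), compound 1 gives only a limit, > 10000 nM. In this assay compound 2 likewise gives only a limit, > 10000 nM. Both values thus sit at the limit of > 10000 nM in this assay, at which 2 of the 2 values shown sit, so compound 2 stands nowhere distinguishable from compound 1. Compound 3 `CCCCCN1CCN(c2nc(N)nc3sc(-c4ccc(F)cc4)nc23)CC1` carries the change (pentyl in place of phenylsulfonyl on an amine nitrogen in a ring). Going by the values given here, no measured step covers such a swap, so the step from compound 2 to compound 3 in this assay is expected to be none beyond the scatter: a number no higher from compound 2 to compound 3 (the limit leaves the size open). For compound 3 in this assay the estimate is 10000 nM, within 3000 nM to 30000 nM.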

Compound 3, half-maximal inhibitory concentration: > 10000 nM
Compound 3: only a limit was reported; the forecaster's own chance of this, stated with the estimate: 70%; the middle value lies on the limit itself.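

The step between compound 2 and compound 3 cannot be read, as this assay gives only limits for both: the limit of > 10000 nM in this assay, at which 3 of the 3 values shown sit.

The compounds shown leave open whether any group on this ring nitrogen gives a measurable inhibitory value.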